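The source may hold more compounds than are shown below. What is called first, only, known or untested is meant among the compounds shown, and "the series" means these compounds.

Three compounds from this series were examined in a functional assay on the whole organism (Ehrlich cells, Mus musculus) for antiproliferative activity, with a stated time of 24 h, at a dose of 0.2 mmol/kg by the intraperitoneal route; on this read-out higher numbers stand for more inhibition at the one dose given (going by the name of the read-out) and lower numbers for less inhibition. Compound 1 `Nc1ccccc1NC(=O)CCCNCC(=O)Nc1ccc(Cl)cc1` gives 72.7% in this assay. Compound 2 `COc1ccc(NC(=O)CNc2ccc(C(=O)Nc3ccccc3N)cc2)cc1` gives 66.6% in this assay, and compound 3 `COc1ccc(NC(=O)CNCCCC(=O)Nc2ccccc2N)cc1` gives 63.8% in this assay. The three numbers all lie within the usual scatter of one another, so none of these compounds can be set apart as giving a higher or lower number than the others on this read-out.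

Compound 3 and compound 1 differ in a single place: chloro in place of methoxy on an aromatic carbon This change produced a step of a number 8.9 percentage points higher from compound 3 to compound 1 (within the scatter) in this assay, a movement that stays within the scatter.

The unmeasured compound 4 `Nc1ccccc1NC(=O)c1ccc(NCC(=O)Nc2ccc(Cl)cc2)cc1` arises from compound 2 by the same change: chloro in place of methoxy on an aromatic carbon The place is described in identical words for both pairs, and the change occurs twice among the compounds shown. How the core of compound 2 differs from the core of compound 3 is not broken down here.

The step of a number 8.9 percentage points higher from compound 3 to compound 1 (within the scatter) remained within the scatter, and the only basis for an expectation is that single step. On that basis the expected step from compound 2 to compound 4 is estimated as a number 6.4 percentage points higher from compound 2 to compound 4 (within the scatter), of about the same size as the earlier one. Compound 4 is therefore estimated to give 73% in this assay, expected to fall between 61% and 84%.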

Compound 4, a percentage reported as inhibition, in the whole organism at one dose (the size of the read-out at that dose, not a potency): 79.4%
Compound 4: middle estimate off by 6.4 percentage points, on the low side; low and high end bracket the measured number.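

In this assay, among these compounds, the change from 4-methoxyphenyl to 4-chlorophenyl on the core of compound 2 gave a number 12.8 percentage points higher from compound 2 to compound 4 (beyond the scatter), the first step in this small set to clear the scatter. Among the compounds shown here, the same change moved the number in the same direction on both cores, and the two steps cannot be told apart in size, so carrying it from one core to the other held up in these two pairs: the same change on two cores in this assay, a number 8.9 percentage points higher (within the scatter) from compound 3 to compound 1 and a number 12.8 percentage points higher (beyond the scatter) from compound 2 to compound 4, 3.9 percentage points apart, within the scatter of two such steps This does not show that the change has the same effect on every core, since it rests on only two pairs, one of which stays within the scatter on its own, and the read-out gives the size of the inhibition at one dose rather than a potency or any reason for the step.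

The compounds shown leave open whether a bromo, a trifluoromethyl or a plain hydrogen in the same place would read closer to chloro or to methoxy. They also leave open whether the step would persist on a core with a longer chain, or at other doses and times in the same whole-organism test.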